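A few compounds are considered here, and "the series" means these few. Any claim that something is new, unique, unknown or untested is made for them only; others in the source may bear on it.

In an assay on HEK293 cells for inhibition of Steryl-sulfatase (Homo sapiens), tested at 0.1 uM (on this read-out higher numbers stand for a stronger effect at the one concentration tested and lower numbers for a weaker effect), three compounds have been measured so far:
compound 1 `NS(=O)(=O)Oc1ccc2c(c1)CN(C(=O)c1ccc(N(Cc3ccccc3)Cc3ccco3)cc1)CC2` gives 90.8%;
compound 2 `CCN(Cc1ccc(Br)cc1)c1ccc(C(=O)N2CCc3ccc(OS(N)(=O)=O)cc3C2)cc1` gives 78.2%;
compound 3 `CCN(Cc1ccncc1)c1ccc(C(=O)N2CCc3ccc(OS(N)(=O)=O)cc3C2)cc1` gives 47%.

Compound 3 stands lowest of the three in this assay: compound 2 lies beyond the scatter above it, and compound 1 further above still. All three share the same core and differ only in the two groups carried by the nitrogen on the aromatic ring.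

Compound 4 `CCCN(Cc1ccccc1)c1ccc(C(=O)N2CCc3ccc(OS(N)(=O)=O)cc3C2)cc1` has not yet been measured. It differs from compound 3 in one place: benzyl(propyl)amino in place of ethyl((pyridin-4-yl)methyl)amino on an aromatic carbon.

Going by the values given here, one measured step bears on this change. From compound 2 to compound 3 the read-out fell by a number 31.2 percentage points lower from compound 2 to compound 3 (beyond the scatter), when a pyridin-4-yl took the place of a 4-bromophenyl on the chain carbon bound to that nitrogen. Compound 4 moves the other way, back to a six-membered aromatic ring of carbon only, and its benzyl group is also present in compound 1, which gives the highest number of the three. Among the compounds with values here, an upward step beyond the scatter is therefore expected, of roughly the size seen between compound 2 and compound 3, though the propyl in place of ethyl has no measured counterpart here.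

Compound 4 is expected to give about 80% in this assay, within 65% to 92%. This estimate means a step of a number 33 percentage points higher from compound 3 to compound 4 (beyond the scatter) from compound 3 to compound 4.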

Compound 4, a percentage reported as inhibition, at one concentration (the size of the read-out at that concentration, not a potency): 64.8%
The estimate for compound 4 lay 15.2 percentage points above the measured number, and the stated range ends above it.
By their numbers in this assay, from the lowest: compound 3; then compound 4; then compound 2; then compound 1.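

Swapping ethyl((pyridin-4-yl)methyl)amino for benzyl(propyl)amino on this aromatic carbon gives a number 17.8 percentage points higher from compound 3 to compound 4 (beyond the scatter) in this assay, so a group with a six-membered aromatic ring of carbon only can stand above the pyridine-bearing compound 3 here. Yet a carbon-only ring does not by itself restore the higher numbers: benzyl(propyl)amino in place of (4-bromobenzyl)(ethyl)amino gives a number 13.4 percentage points lower from compound 2 to compound 4 (beyond the scatter), and ethyl in place of furan-2-yl on the chain carbon bound to the nitrogen gives a number 26 percentage points lower from compound 1 to compound 4 (beyond the scatter), which shows that the second group on that nitrogen matters even with the benzyl group held constant. No measurement at hand explains why these changes shift the read-out as they do.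

Compound 4 differs from compound 3 in both the ring and the chain length, so the shares of the ring swap and the propyl in place of ethyl cannot be separated. As far as these compounds go, it also remains open how the read-out would respond to a 4-chlorobenzyl or 4-methoxybenzyl group on the nitrogen, or to a butyl chain or thiophen-2-ylmethyl group as its second substituent.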